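Vinyl replaces thiophen-3-yl on a quinolinone carboxamide

This account rests on a few compounds, and the source may have more. Where it says the series, first, only, none or still open, it means among the compounds named here.

Measured compounds:
compound 1, `O=C(Nc1cc(F)c(F)c(F)c1)c1cc(=O)[nH]c2cc(Br)ccc12`, > 20000 nM
compound 2, `O=C(Nc1cccc(F)c1)c1cc(=O)[nH]c2cc(-c3ccsc3)ccc12`, 5100 nM

Compound 1, `O=C(Nc1cc(F)c(F)c(F)c1)c1cc(=O)[nH]c2cc(Br)ccc12`, reaches only the limit of a functional assay on KYSE-70 cells for antiproliferative activity against KYSE-70 cell line (Homo sapiens), read by MTT assay, with a stated time of 72 h (a lower number here means a stronger inhibitor, a higher number a weaker inhibitor), giving > 20000 nM, which is a limit of the measurement and not a number; this is the limit of > 20000 nM in this assay, at which 1 of the 2 values shown sits. Among the compounds with values here, compound 2, `O=C(Nc1cccc(F)c1)c1cc(=O)[nH]c2cc(-c3ccsc3)ccc12`, gives 5100 nM in this assay, the only numerical value shown. Compound 3, `C=Cc1ccc2c(C(=O)Nc3cccc(F)c3)cc(=O)[nH]c2c1`, has not yet been measured. It differs from compound 2 in one place: vinyl in place of thiophen-3-yl on an aromatic carbon. No step between measured compounds that differ in one place is shown, so the size of this change in this assay is not known from the data. Compound 3 is expected to sit close to compound 2 or somewhat weaker, a step of a 1.6-fold higher number from compound 2 to compound 3 (0.20 log units; within the scatter). Compound 3 is estimated at 8000 nM, within 2500 nM to 30000 nM.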

Compound 3, half-maximal inhibitory concentration: 9700 nM
Estimate against measurement, compound 3: 1.2-fold (0.08 log units) below; the measured number falls inside the stated range.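

In this assay the first step readable at this aromatic carbon is a 1.9-fold higher number from compound 2 to compound 3 (0.28 log units; within the scatter), so the two values lie within the usual scatter of each other. The data therefore do not separate thiophen-3-yl, a five-membered aromatic ring, from vinyl, which has no ring, and a ring at this carbon is not needed for a numerical value in this assay. Compound 1 differs from the other two in more than one place, so it offers no comparison for this change, and its value is a limit of the measurement and not a number: the limit of > 20000 nM in this assay, at which 1 of the 3 values shown sits.

From the compounds shown here alone, whether an amine, a carboxylic acid or a longer alkyl chain on this aromatic carbon would shift the value beyond the scatter remains open. Also open, going by these compounds, is whether the same exchange would give a step within the scatter with a different ring on the amide.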